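A Chloro-Hydroxyphenyl Analogue and Its Expected Clearance

The compounds below may be only part of what the source reports. "The series", "measured", "known", "first", "only" and "open" are said of these compounds alone.

Compound 1 `COc1ccc(C(=O)N2CCC(=CC(=O)N[C@@H]3CCN(Cc4ccc5cc(F)ccc5c4)C3)CC2)cc1OC` gives 246 mL/min/kg in an in vitro ADME assay on microsomes from liver (Homo sapiens) for metabolic stability; a higher number here means faster removal of the compound, a lower number slower removal.
Compound 2 `COc1ccc(C(=O)N2CCC(=CC(=O)N[C@@H]3CCN(Cc4ccc5cc(F)ccc5c4)C3)CC2)c(O)c1` gives 232 mL/min/kg in this assay.
Compound 3 `COc1cccc(C(=O)N2CCC(=CC(=O)N[C@@H]3CCN(Cc4ccc5cc(F)ccc5c4)C3)CC2)c1O` gives 162 mL/min/kg in this assay.

The three compounds share one core and differ only in the aromatic ring attached to a carbonyl carbon. The step of a 1.1-fold lower number from compound 1 to compound 2 (0.03 log units; within the scatter) and the step of a 1.5-fold lower number from compound 1 to compound 3 (0.18 log units; within the scatter) both stay within the scatter, as does the step of a 1.4-fold lower number from compound 2 to compound 3 (0.16 log units; within the scatter). Compound 3 has the smallest number of the three as written, but since every gap to the other two lies within the scatter, the three compounds cannot be told apart in this assay.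

Compound 4 `O=C(C=C1CCN(C(=O)c2ccc(Cl)cc2O)CC1)N[C@@H]1CCN(Cc2ccc3cc(F)ccc3c2)C1` is the next member. Its difference from compound 3 is 4-chloro-2-hydroxyphenyl in place of 2-hydroxy-3-methoxyphenyl on a carbonyl carbon.

Every measured step in this set rearranges the same ring on the same carbonyl carbon, and none moved the number beyond the scatter. Among the compounds with values here, no measured step introduces chlorine, so the change to compound 4 is only partly covered, but the available evidence points to a small shift at most. The expected step is a 1.2-fold higher number from compound 3 to compound 4 (0.07 log units; within the scatter), within the scatter. Compound 4 is therefore estimated at 190 mL/min/kg, with a range from 100 mL/min/kg to 360 mL/min/kg.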

Compound 4, clearance: 87 mL/min/kg
Compound 4: the middle estimate sits 2.2-fold (0.34 log units) above what was measured; the measured number lies below the stated range.
By their numbers in this assay, from the lowest: compounds 4, 3, 2 and 1 (each within the scatter of the next, the first and the last beyond it).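

Chloro in place of methoxy on an aromatic carbon gives the first step in this set to pass the usual scatter in this assay (a 2.7-fold lower number from compound 2 to compound 4 (0.43 log units; beyond the scatter)), so the aromatic ring on this carbonyl carbon can affect the clearance after all. The swap of 4-chloro-2-hydroxyphenyl for 3,4-dimethoxyphenyl also passes the scatter (a 2.8-fold lower number from compound 1 to compound 4 (0.45 log units; beyond the scatter)), whereas the swap for 2-hydroxy-3-methoxyphenyl stays within it (a 1.9-fold lower number from compound 3 to compound 4 (0.27 log units; within the scatter)), so compound 3 and compound 4 cannot be separated and the clear gaps are to the two other compounds only. Nothing available here explains why the chloro compound stands apart from those two.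

As far as these compounds go, whether the step belongs to chlorine in particular remains open, as does the question of whether a fluoro, a methyl or an amino group in the same place would give a similar number. Also open, from the compounds shown here alone, is whether the step depends on the hydroxy group shared by compound 2 and compound 4, since all that is known about chloro here rests on compound 4 alone.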